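A few compounds are considered here, and "the series" means these few. Any claim that something is new, unique, unknown or untested is made for them only; others in the source may bear on it.

In an ADME assay on BaF3 cells (Mus musculus) for cytotoxicity (a higher number here means that more compound is needed for the effect, a lower number that less compound is needed), compound 1 `CCN1CCN(Cc2ccc(NC(=O)c3cccc(-c4ccc5nc(N)sc5n4)c3)cc2C(F)(F)F)CC1` reports only a limit, > 10000 nM. Compound 2 `O=C(Nc1ccc(N2CCNCC2)c(C(F)(F)F)c1)c1cccc(-c2ccc3nc(NC(=O)C4CC4)sc3n2)c1` gives 2300 nM. Compound 3 `Cc1cn(-c2cc(NC(=O)c3ccc(C)c(-c4ccc5nc(NC(=O)C6CC6)sc5n4)c3)cc(C(F)(F)F)c2)cn1` gives 4670 nM, the higher of the two actual numbers, and its gap to compound 2 lies beyond the scatter. Compound 4 `Cc1cn(-c2cc(NC(=O)c3ccc(F)c(-c4ccc5nc(NC(=O)C6CC6)sc5n4)c3)cc(C(F)(F)F)c2)cn1` differs from compound 3 in a single substituent, with fluoro in place of methyl on an aromatic carbon, ortho to a large group and para to a large group (fluoro in place of methyl on an aromatic carbon). Within the data shown here, no measured pair shows a change of this kind. The expected step of a 1.2-fold lower number from compound 3 to compound 4 (0.07 log units; within the scatter) is small and stays within the scatter, with no firm direction. For compound 4 the estimated value is 4000 nM, with an expected range of 1500 nM to 10000 nM.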

Compound 4, half-maximal effective concentration: > 10000 nM
Compound 4 gave a limit, no number; the forecaster's own chance of this, stated with the estimate: 10%; at least 2.5-fold (0.39 log units) between middle value and limit.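

In this assay, fluoro in place of methyl on an aromatic carbon, ortho to a large group and para to a large group, gives an at least 2.1-fold higher number from compound 3 to compound 4 (0.33 log units; beyond the scatter). Among these compounds, this is the first reading of a change at this position, and a one-atom exchange there moves the result beyond the scatter. Compound 4 stands at a limit, so the step has a lower bound only: the limit of > 10000 nM in this assay, at which 2 of the 4 values shown sit.

The compounds shown leave open how chloro, methoxy or an amine on this carbon would read. They also leave open whether this exchange gives a similar step with other groups on the rest of the molecule.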